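The source may hold more compounds than are shown below. What is called first, only, known or untested is meant among the compounds shown, and "the series" means these compounds.

Compound 1 `CC1(C)[C@@H]2CC3=N[C@@H](CCC(=O)O)C(=O)O[C@@]3(C)[C@H]1C2`, compound 2 `C[C@@H]1N=C2C[C@@H]3C[C@@H](C3(C)C)[C@]2(C)OC1=O` and compound 3 `CC1(C)[C@H]2CC3=NCC(=O)O[C@]3(C)[C@@H]1C2` share one core and differ only in what hangs from it. In an ADME assay on McCoy cells (Mus musculus) for antiproliferative activity, read by sulforhodamine B assay, with a stated time of 48 h (on this read-out lower numbers stand for stronger inhibition and higher numbers for weaker inhibition), compound 1 reaches only the limit of the assay, > 1200000 nM. Compound 2 likewise reaches only a limit, > 2000000 nM. Compound 3 too reaches only a limit, > 2000000 nM. For the measured compounds named here, the one step among them, a step that the two limits leave unreadable from compound 1 to compound 2, hydrogen in place of carboxymethyl, cannot be sized, as both values sit at limits the limit of > 1200000 nM in this assay, at which 1 of the 3 values shown sits, and (the limit of > 2000000 nM in this assay, at which 2 of the 3 values shown sit). Compound 3 therefore stands where every value shown stands: at a limit, not a number. Compound 4 `CC1(C)[C@@H]2CC3=NCC(=O)O[C@@]3(C)[C@H]1C2` differs from compound 3 only in configuration: the two compounds have the same atoms and bonds and differ only in configuration as drawn: 3 of 3 stereo elements differ (all stereocentres are inverted: mirror images); a stereocentre at a saturated ring carbon is drawn R in compound 3 and S in compound 4; a stereocentre at a saturated ring carbon is drawn R in compound 3 and S in compound 4; a stereocentre at a saturated ring carbon is drawn R in compound 3 and S in compound 4. Going by the values given here, no measured step bears on an inversion of all stereocentres, and none of the measured steps could be read at all, so no step beyond the scatter is expected in this assay. The step of a number no higher from compound 3 to compound 4 (the limit leaves the size open) is expected to be about nothing. Compound 4 is expected to give 2000000 nM, within 800000 nM to 5000000 nM, most probably again as a limit.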

Compound 4, half-maximal inhibitory concentration: > 900000 nM
Compound 4: only a limit was reported; the forecaster's own chance of this, stated with the estimate: 85%; the middle value is on the limit's open side.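

Compound 4 gives only a limit, > 900000 nM, and its steps to compound 1, compound 2 and compound 3, which also stand at limits, cannot be read. The compounds shown leave open whether the mirror images compound 3 and compound 4 differ at all, and at what concentration any of the four would inhibit.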